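The source may hold more compounds than are shown below. What is called first, only, known or untested is meant among the compounds shown, and "the series" means these compounds.

Measured in a functional assay on Caco-2 cells (Homo sapiens) for inhibition, read by MTT assay, with a stated time of 48 h, tested at 10 uM; a higher number here means more inhibition of growth at the concentration tested, a lower number less inhibition of growth:
compound 1 `Cc1cc(=O)c2c(O)cc(OCc3ccco3)c([C@H]3CCN(C)C[C@H]3O)c2o1`: 17%
compound 2 `CCN(CC)Cc1c(O)c([C@H]2CCN(C)C[C@H]2O)c2oc(C)cc(=O)c2c1O`: 17%
compound 3 `Cc1cc(=O)c2c(O)c(CN(C)CC(=O)O)c(O)c([C@H]3CCN(C)C[C@H]3O)c2o1`: 18%

Compound 3 stands level with the other two compounds. Its 18% lies within the scatter of both, so this assay does not separate any of the three.

The next structure, compound 4 `Cc1cc(=O)c2c(O)c(CN(C(C)C)C(C)C)c(O)c([C@H]3CCN(C)C[C@H]3O)c2o1`, differs from compound 3 in one place: diisopropylamino in place of (carboxymethyl)(methyl)amino on a saturated chain carbon bound to an aromatic carbon. In words, it carries diisopropylamino in place of (carboxymethyl)(methyl)amino on a saturated chain carbon bound to an aromatic carbon.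

Within the data shown here, only one measured step bears on this change: a number 1 percentage points higher from compound 2 to compound 3 (within the scatter). That step brought in the same (carboxymethyl)(methyl)amino at the same place, with diethylamino leaving. The move to compound 4 therefore runs the opposite way, towards a group closer to diethylamino. Among the measured compounds shown here, the measured step was small, but no measured compound carries diisopropylamino, so the evidence is thin and the range has to stay generous. No change beyond the scatter is expected in this assay, and no direction can be favoured. The expected step is no change at the digits printed from compound 3 to compound 4 (within the scatter). For compound 4 the estimated value is 18%, with an expected range from 8% to 30%.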

Compound 4, percent growth inhibition at one concentration: 22%
Estimate against measurement, compound 4: 4 percentage points below; low and high end bracket the measured number.
By their numbers in this assay, from the lowest: compounds 1, 2, 3 and 4 (each within the scatter of the next).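

In this assay, the exchange of (carboxymethyl)(methyl)amino for diisopropylamino on a saturated chain carbon bound to an aromatic carbon gives a number 4 percentage points higher from compound 3 to compound 4 (within the scatter), and the exchange of diethylamino for diisopropylamino gives a number 5 percentage points higher from compound 2 to compound 4 (within the scatter). This place therefore now holds three different amino groups without any step leaving the scatter, and that includes the exchange that removes the carboxymethyl arm with its hydrogen-bond donor, so neither that arm nor the isopropyl groups separate these compounds in this assay. Nothing shown here gives a reason for these numbers.

On these data alone, whether a ring amine at this place, such as morpholine or piperidine, or a benzyl group on the nitrogen would produce a step beyond the scatter remains open. Also open, as far as these compounds go, is how these amino groups would compare at a concentration other than the single one used in this read-out, since one concentration cannot show whether differences hidden within the scatter here would appear elsewhere.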